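One Added Group on Compound 1: What to Expect

The source may report more compounds than this note shows. Statements on the series, on what has been measured and on what is new or still open speak of the compounds shown alone.

Measured so far:
- compound 1, `O=C(/C=C/c1ccc(I)cc1)c1ccc(O)cc1`, gives 30000 nM in a functional assay on MCF-12A cells (Homo sapiens) for inhibition; on this read-out higher numbers stand for weaker inhibition and lower numbers for stronger inhibition
- compound 2, `O=C(/C=C/c1ccc(B(O)O)cc1)c1ccc(Cl)c(Cl)c1`, gives 15000 nM in this assay

Compound 1 has the highest number of the two, but its nearest neighbour, compound 2, sits within the usual scatter, so the two values cannot be ordered with confidence. Compound 3, `O=C(/C=C/c1ccc(I)cc1)c1ccc(OCB(O)O)cc1`, carries a group of 4 heavy atoms (1 carbon, 1 boron, 2 oxygen; no ring) in place of a hydrogen atom, on an oxygen on an aromatic ring. Within the data shown here, no measured pair shows this change, so its effect is unknown. The step from compound 1 to compound 3 in this assay is expected to be small, estimated as a 2.0-fold lower number from compound 1 to compound 3 (0.30 log units; within the scatter), towards stronger inhibition but not clearly beyond the scatter. For compound 3 the estimate is 15000 nM, within 5000 nM to 45000 nM.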

Compound 3, half-maximal inhibitory concentration: 100000 nM
The estimate for compound 3 lay 6.7-fold (0.82 log units) below the measured number, and the stated range ends below it.
By their numbers in this assay, from the lowest: compounds 2 and 1 (each within the scatter of the next); then compound 3.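

Putting this group of 4 heavy atoms, which holds the boron, in place of the hydrogen atom on the oxygen gives a 3.3-fold higher number from compound 1 to compound 3 (0.52 log units; beyond the scatter) in this assay, a move towards weaker inhibition. Among these compounds, this is the first sign that a change at this oxygen can shift the read-out beyond the scatter. Nothing measured here explains the weakening.

On these data alone, whether a methyl group, a longer carbon chain or a carboxylic acid on the same oxygen would weaken inhibition as well remains open. So does whether the boron itself matters, or only the added group as a whole.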